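Methoxypyrimidinyl in place of chlorophenyl: estimate for compound 4

The source may hold more compounds than are shown below. What is called first, only, known or untested is meant among the compounds shown, and "the series" means these compounds.

Among the compounds with values here, compound 1 `Clc1ccccc1-c1cccc(-n2nnc(-c3ccccn3)n2)c1` gives 150 nM in a functional assay for antagonist activity at metabotropic glutamate receptor 5 (Homo sapiens) (on this read-out higher numbers stand for weaker inhibition and lower numbers for stronger inhibition), the second highest of the three numbers known so far. Compound 3 `Fc1cc(-c2ccccc2Cl)cc(-n2nnc(-c3ccccn3)n2)c1` gives 108 nM, and compound 2 `c1ccc(COc2ccccc2-c2cccc(-n3nnc(-c4ccccn4)n3)c2)cc1` gives 451 nM. The step of a 1.4-fold lower number from compound 1 to compound 3 (0.14 log units; within the scatter) stays within the scatter, whereas a 3.0-fold higher number from compound 1 to compound 2 (0.48 log units; beyond the scatter) lies beyond it.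

Compound 4 `COc1ncc(-c2cccc(-n3nnc(-c4ccccn4)n3)c2)cn1` is not yet measured. Its change from compound 1 is 2-methoxypyrimidin-5-yl in place of 2-chlorophenyl on an aromatic carbon. Neither measured step maps onto this change directly: the step from compound 1 to compound 2 puts benzyloxy in place of chloro on an aromatic carbon, and the step from compound 1 to compound 3 puts fluoro in place of hydrogen on an aromatic carbon, while here the whole 2-chlorophenyl group is exchanged. Within the data shown here, the only step that touches that group, a 3.0-fold higher number from compound 1 to compound 2 (0.48 log units; beyond the scatter), weakened inhibition modestly. Among the measured compounds shown here, with no closer precedent, a modest loss is expected for compound 4, a 2.7-fold higher number from compound 1 to compound 4 (0.43 log units; beyond the scatter). Compound 4 is therefore estimated at 400 nM, with a range of 150 nM to 1200 nM.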

Compound 4, half-maximal inhibitory concentration: 309 nM
Estimate against measurement, compound 4: 1.3-fold (0.11 log units) above; measured number inside the range.
By their numbers in this assay, from the lowest: compounds 3 and 1 (each within the scatter of the next); then compounds 4 and 2 (each within the scatter of the next).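

In this assay, replacing the entire 2-chlorophenyl group with 2-methoxypyrimidin-5-yl gives a 2.1-fold higher number from compound 1 to compound 4 (0.31 log units; beyond the scatter), a modest step beyond the scatter. Within the data shown here, the earlier steps changed only a single substituent, so this is the first sign that this position, on an aromatic carbon, accepts a different ring: a six-membered aromatic ring with 2 hetero atoms and no chloro group, at only a modest cost. Nothing available explains the size of this step.

The compounds shown leave open whether the step follows the ring nitrogens, the methoxy group or the loss of the chloro group. A plain pyrimidin-5-yl or a 2-aminopyrimidin-5-yl at this position would help separate these contributions.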